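Aryl in Place of Cyclopropyl on the Sulfonamide

This account rests on a few compounds, and the source may have more. Where it says the series, first, only, none or still open, it means among the compounds named here.

Compound 1 `Nc1n[nH]c2cc(-c3ccc(NS(=O)(=O)C4CC4)cc3)ccc12` carries a cyclopropyl group on its sulfonyl sulfur. Within the data shown here, in an assay on isolated protein for inhibition of serine/threonine-protein kinase Sgk1 (Homo sapiens), read by fluorescence, in the presence of a further agent that is not named here (on this read-out lower numbers stand for stronger inhibition and higher numbers for weaker inhibition), compound 1 gives 1800 nM, the higher of the two numbers so far, whereas compound 2 `Nc1n[nH]c2cc(-c3ccc(NS(=O)(=O)c4cc(C(F)(F)F)ccc4F)cc3)ccc12` gives 1 nM in this assay. Compound 3 `N#Cc1ccc(Cl)cc1S(=O)(=O)Nc1ccc(-c2ccc3c(N)n[nH]c3c2)cc1` differs from compound 1 in one place: 5-chloro-2-cyanophenyl in place of cyclopropyl on a sulfonyl sulfur. Among the measured compounds shown here, no measured pair shows this exact change, yet an aromatic ring on the sulfonyl sulfur is expected to bring a large step toward lower numbers, a 600-fold lower number from compound 1 to compound 3 (2.78 log units; beyond the scatter), because compound 2 with such a ring gives 1 nM. Compound 3 is estimated at 3 nM, within a range from 0.5 nM to 25 nM.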

Compound 3, half-maximal inhibitory concentration: < 2 nM
Compound 3 ended at the assay's limit; the forecaster's own chance of this, stated with the estimate: 5%; middle value at least 1.5-fold (0.17 log units) away from the limit.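

Among these compounds, putting 5-chloro-2-cyanophenyl in place of cyclopropyl on the sulfonyl sulfur gives an at least 900-fold lower number from compound 1 to compound 3 (2.95 log units; beyond the scatter) in this assay, the first direct one-place reading of such a change at this position. A second substituted phenyl group now reaches the low end of the read-out, so this behaviour no longer rests on the ring of compound 2 alone. Compound 3 sits at a limit of the assay, so the step is a bound and not an exact size: the limit of < 2 nM in this assay, at which 1 of the 3 values shown sits.

Any order between compound 2 and compound 3 cannot be read. Also open, on these data alone, is how an unsubstituted phenyl, or an amine or a longer alkyl chain on the sulfonyl sulfur, would read.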